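One Methyl Less: From Compound 2 to Compound 3

This account rests on a few compounds, and the source may have more. Where it says the series, first, only, none or still open, it means among the compounds named here.

Compound 1, `CC(C)OC(=O)[C@H](CCC(=O)C=[N+]=[N-])NC(=O)OCOC(=O)C(C)(C)C`: 9%
Compound 2, `CC(C)[C@H](N)C(=O)N[C@@H](CCC(=O)C=[N+]=[N-])C(=O)OCc1c[nH]c2ccccc12`: 30%

In an ADME assay on a cell-free system (plasma, Homo sapiens) for metabolic stability, read by LC-MS, with a stated time of 60 min, tested at 10 uM (a higher number here means that more of the compound is left, a lower number that less of the compound is left), compound 2 gives 30%, the highest of the two numbers, and compound 1 gives 9%, a gap beyond the scatter. Compound 1 and compound 2 differ in many places, so only their two values can be read. Compound 3, `CC[C@H](N)C(=O)N[C@@H](CCC(=O)C=[N+]=[N-])C(=O)OCc1c[nH]c2ccccc12`, differs from compound 2 by hydrogen in place of methyl on a saturated chain carbon bound to two saturated chain carbons. Going by the values given here, no measured pair shows this change. A small drop is expected, not beyond the scatter, as the step of a number 5 percentage points lower from compound 2 to compound 3 (within the scatter). Compound 3 is expected to give 25%, between 10% and 45%.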

Compound 3, percent of the compound remaining: 12%
Beside the measured number, compound 3's estimate is 13 percentage points above it; low and high end bracket the measured number.
By their numbers in this assay, from the lowest: compounds 1 and 3 (each within the scatter of the next); then compound 2.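

In this assay, going by these compounds alone, the change from isopropyl to ethyl gives a number 18 percentage points lower from compound 2 to compound 3 (beyond the scatter) as the first comparison that differs in one place. Losing one methyl on a saturated chain carbon bound to two saturated chain carbons therefore moves this read-out beyond the scatter, which the earlier pair, differing in many places, could not show. Nothing at hand bears on the reason for this drop.

The compounds shown leave open how a longer chain or a cyclohexyl group would read in this place. They also leave open whether the same change gives a similar step on another core.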